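A few compounds are considered here, and "the series" means these few. Any claim that something is new, unique, unknown or untested is made for them only; others in the source may bear on it.

Measured compounds:
- compound 1 `O=C(Nc1ccccc1)C1CCN(C/C=C/c2ccccc2)CC1`: 69700 nM
- compound 2 `N#Cc1ccc(NC(=O)C2CCN(C/C=C/c3ccccc3)CC2)cc1`: 40200 nM

Both values come from a functional assay on A549 cells (Homo sapiens) for inhibition, read by MTT assay, with a stated time of 72 h; a higher number here means a weaker inhibitor, a lower number a stronger inhibitor. Among the measured compounds shown here, on these numbers compound 2 cannot be told apart from the only other measured compound, and the one step available is a 1.7-fold lower number from compound 1 to compound 2 (0.24 log units; within the scatter). That step put cyano in place of hydrogen on an aromatic carbon.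

The next compound is compound 3 `CN1CCN(c2ccc(NC(=O)C3CCN(C/C=C/c4ccccc4)CC3)cc2)CC1`, with 4-methylpiperazin-1-yl in place of cyano on an aromatic carbon, para to a large group: 4-methylpiperazin-1-yl in place of cyano on an aromatic carbon.

For the measured compounds named here, no measured compound carries this group, so the single step above is the only guide, and it stayed within the scatter. No step beyond the scatter is therefore expected in this assay, and neither direction is favoured with any confidence. The expected step is a 1.1-fold lower number from compound 2 to compound 3 (0.06 log units; within the scatter). For compound 3 the estimated value is 35000 nM, with an expected range of 10000 nM to 90000 nM.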

Compound 3, half-maximal inhibitory concentration: 19900 nM
The estimate for compound 3 lay 1.8-fold (0.25 log units) above the measured number, within the range that was stated.
By their numbers in this assay, from the lowest: compound 3; then compounds 2 and 1 (each within the scatter of the next).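

In this assay the aromatic carbon para to a large group now yields steps beyond the scatter: 4-methylpiperazin-1-yl in place of cyano gives a 2.0-fold lower number from compound 2 to compound 3 (0.31 log units; beyond the scatter) and in place of hydrogen gives a 3.5-fold lower number from compound 1 to compound 3 (0.54 log units; beyond the scatter), both modest. Among the compounds shown here, compound 2 could not show this, as its only step, from compound 1, stayed within the scatter; the change at this position can therefore move the number, though compound 3 is the only compound showing it. No measurement shown here accounts for this step.

The compounds shown leave open whether the step needs the whole 4-methylpiperazin-1-yl group or only part of it. A morpholine or an unsubstituted piperazine at the same position would bear on that, and a dimethylamino group would test whether the ring is needed at all.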